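Moving a methoxy group on the end of a long chain

A few compounds are considered here, and "the series" means these few. Any claim that something is new, unique, unknown or untested is made for them only; others in the source may bear on it.

In a functional assay on HT-29 cells (Homo sapiens) for inhibition, read by MTT assay, with a stated time of 3 days (a higher number here means a weaker inhibitor, a lower number a stronger inhibitor), compound 1 `COc1ccc(/C=C\c2cc(OC)c(OC)c(OC)c2)cc1OCc1ccccc1` gives 39000 nM and compound 2 `COc1ccc(/C=C\c2cc(OC)c(OC)c(OC)c2)cc1OCc1ccc(Br)cc1` gives 108000 nM. Compound 3 `COc1cccc(/C=C/CCCOc2cc(/C=C\c3cc(OC)c(OC)c(OC)c3)ccc2OC)c1` gives 25000 nM. That puts it level with one neighbour, a 1.6-fold lower number from compound 1 to compound 3 (0.19 log units; within the scatter), and clearly better than the other, a 4.3-fold lower number from compound 2 to compound 3 (0.64 log units; beyond the scatter). Compound 4 `COc1ccc(/C=C/CCCOc2cc(/C=C\c3cc(OC)c(OC)c(OC)c3)ccc2OC)cc1` carries 4-methoxyphenyl in place of 3-methoxyphenyl on a double-bonded chain carbon bound to a double-bonded chain carbon. Among the compounds with values here, no measured pair shows a methoxy group changing place. The nearest guide is a different change, bromo in place of hydrogen, which gave only a modest 2.8-fold higher number from compound 1 to compound 2 (0.44 log units; beyond the scatter). The expected outcome is therefore no step beyond the scatter, a 1.2-fold higher number from compound 3 to compound 4 (0.08 log units; within the scatter). The estimate for compound 4 is 30000 nM, within a range of 10000 nM to 80000 nM.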

Compound 4, half-maximal inhibitory concentration: 47000 nM
Compound 4: middle estimate off by 1.6-fold (0.19 log units), on the low side; the range from low to high includes it.
By their numbers in this assay, from the lowest: compounds 3, 1 and 4 (each within the scatter of the next); then compound 2.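

Changing 3-methoxyphenyl to 4-methoxyphenyl on this double-bonded chain carbon gives no step beyond the scatter in this assay (a 1.9-fold higher number from compound 3 to compound 4 (0.27 log units; within the scatter)), so here the methoxy group can change place without a clear change in the number. The 4-(4-methoxyphenyl)but-3-en-1-yl chain stands level with phenyl (a 1.2-fold higher number from compound 1 to compound 4 (0.08 log units; within the scatter)) and, like the 3-methoxy chain, does better than 4-bromophenyl (a 2.3-fold lower number from compound 2 to compound 4 (0.36 log units; beyond the scatter)). No measurement at hand explains these numbers.

Still open, on these data alone, is whether an amine or a carboxylic acid in place of the methoxy group would give a step beyond the scatter. The same question stands for a longer chain.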